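Sulfonyl substituent change in a weak growth inhibition series

This account rests on a few compounds, and the source may have more. Where it says the series, first, only, none or still open, it means among the compounds named here.

- Compound 1 (`CN(C)c1ccc(/C=C(/Sc2ccccc2Br)C(=O)c2ccc(Br)cc2)cc1`) gives > 100000 nM as a limit
- Compound 2 (`CN(C)c1ccc(/C=C(\C(=O)c2ccc(Br)cc2)S(=O)(=O)Cc2ccc(F)cc2)cc1`) gives 50000 nM as a number
- Compound 3 (`Cc1ccc(S(=O)(=O)/C(=C/c2ccc(N(C)C)cc2)C(=O)c2ccc(Br)cc2)cc1`) is not yet measured

Within the data shown here, in a functional assay on DU-145 cells (Homo sapiens) for inhibition, read by trypan blue exclusion, with a stated time of 96 h (on this read-out lower numbers stand for stronger inhibition of growth and higher numbers for weaker inhibition of growth), compound 2 gives 50000 nM and so holds the only number so far. Compound 1 stands at a limit of the assay (the limit of > 100000 nM in this assay, at which 1 of the 2 values shown sits) and not at a number.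

The change to compound 3 is 4-methylphenyl in place of 4-fluorobenzyl on a sulfonyl sulfur. Among the measured compounds shown here, no two measured compounds differ in one place only, so the data give no step for this change. The expected no change at the digits printed from compound 2 to compound 3 (within the scatter) stays within the usual scatter in this assay with neither direction favoured. Compound 3 is expected at 50000 nM with an estimated range from 20000 nM to 100000 nM as the working figure.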

Compound 3, concentration for 50% growth inhibition: 50000 nM
Beside the measured number, compound 3's estimate shows no gap at the digits printed, and the stated range covers the measured number.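

In this assay, among these compounds, the step on the sulfonyl sulfur, 4-methylphenyl in place of 4-fluorobenzyl, gives no change at the digits printed from compound 2 to compound 3 (within the scatter), the first readable step at this position, and it shows that these two groups cannot be told apart here. On the double-bonded chain carbon, (4-methylphenyl)sulfonyl in place of (2-bromophenyl)sulfanyl gives an at least 2.0-fold lower number from compound 1 to compound 3 (0.30 log units; that floor lies within the scatter), so this change has only a floor and no firm size. Compound 1 stands at a limit and not at a number: the limit of > 100000 nM in this assay, at which 1 of the 3 values shown sits.

From the compounds shown here alone, that second step changes the sulfur and its aryl group together, so the share of each stays open. Also open, going by these compounds, is whether another group on the sulfonyl sulfur, such as a carboxylic acid, an amine or a longer chain, would move the number beyond the scatter.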